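Adding Phenoxy to the Butyl Chain of Compound 3

The compounds below may be only part of what the source reports. "The series", "measured", "known", "first", "only" and "open" are said of these compounds alone.

In a functional assay on HCT-116 cells (Homo sapiens) for antiproliferative activity, read by MTT assay, with a stated time of 48 h (a lower number here means a stronger inhibitor of growth, a higher number a weaker inhibitor of growth), compound 3 `CCCCN(Cc1ccc(C(=O)NO)cc1)c1ncc(-c2ccc(C)cc2)s1` gives 8780 nM. Compound 1 `CCN(Cc1ccc(C(=O)NO)cc1)c1ncc(-c2ccc(C)cc2)s1` gives 6870 nM, and a 1.3-fold higher number from compound 1 to compound 3 (0.11 log units; within the scatter) leaves these two level at the high end of the numbers. Compound 2 `Cc1ccc(OCCCCN(Cc2ccc(C(=O)NO)cc2)c2ncc(-c3ccc(C)cc3)s2)cc1` stands well apart at 580 nM.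

Compound 4 `Cc1ccc(-c2cnc(N(CCCOc3ccccc3)Cc3ccc(C(=O)NO)cc3)s2)cc1` turns the butyl of compound 3 into 3-phenoxypropyl: phenoxy in place of methyl on a saturated chain carbon, three bonds along the chain from a nitrogen on an aromatic ring. The closest guide is the large 15-fold higher number from compound 2 to compound 3 (1.18 log units; beyond the scatter), which runs in the opposite direction and shows what losing 4-methylphenoxy from the chain went with. The a 12-fold lower number from compound 1 to compound 2 (1.07 log units; beyond the scatter) is similarly large. By contrast, a 1.3-fold higher number from compound 1 to compound 3 (0.11 log units; within the scatter) shows no gain from a longer plain chain alone. Compound 4 shares neither the chain nor the methyl of compound 2, and no measurement separates those differences, so only part of that gain is assumed. A large move to a lower number is therefore expected, an estimated 8.8-fold lower number from compound 3 to compound 4 (0.94 log units; beyond the scatter). For compound 4 the expected value is 1000 nM, with an estimated range of 350 nM to 3000 nM.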

Compound 4, concentration for 50% growth inhibition: 4140 nM
For compound 4 the middle estimate is 4.1-fold (0.62 log units) below the measured one, and the stated range ends below it.
By their numbers in this assay, from the lowest: compound 2; then compounds 4, 1 and 3 (each within the scatter of the next, the first and the last beyond it).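

In this assay, phenoxy on the chain gives only a small part of the gain seen with compound 2: a 2.1-fold lower number from compound 3 to compound 4 (0.33 log units; beyond the scatter) is a modest step, and a 7.1-fold higher number from compound 2 to compound 4 (0.85 log units; beyond the scatter) leaves a clear gap. Against the shorter ethyl group, a 1.7-fold lower number from compound 1 to compound 4 (0.22 log units; within the scatter) places compound 4 level with compound 1, so 3-phenoxypropyl at this position does not bring the activity seen with the 4-methylphenoxy-bearing chain of compound 2. Nothing available explains why these chains differ.

Compound 4 differs from compound 2 in both chain length and the methyl on the phenoxy ring, so the compounds shown leave open which of the two goes with the gap. They also leave open how a 4-phenoxybutyl chain, a 3-(4-methylphenoxy)propyl chain, or an amine or carboxylic acid at the chain end would compare.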